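Swapping Bromo for Ethyl on the Anilino Ring

The compounds below may be only part of what the source reports. "The series", "measured", "known", "first", "only" and "open" are said of these compounds alone.

Measured so far:
compound 1, `C=CC(=O)Nc1cccc(NC(=O)CSc2nc(Nc3cccc([N+](=O)[O-])c3)c3ccccc3n2)c1`, gives 22600 nM in a functional assay on NCI-H1975 cells (Homo sapiens) for inhibition, read by MTT assay, with a stated time of 72 h; a higher number here means a weaker inhibitor, a lower number a stronger inhibitor;
compound 2, `C=CC(=O)Nc1cccc(NC(=O)CSc2nc(Nc3ccc(Br)cc3)c3ccccc3n2)c1`, gives 6280 nM in this assay.

Compound 2 holds the lowest of the two numbers, with compound 1 as its nearest neighbour; the step of a 3.6-fold lower number from compound 1 to compound 2 (0.56 log units; beyond the scatter) is modest but beyond the scatter. Compound 3, `C=CC(=O)Nc1cccc(NC(=O)CSc2nc(Nc3ccc(CC)cc3)c3ccccc3n2)c1`, differs from compound 2 by ethyl in place of bromo on an aromatic carbon. Within the data shown here, no measured step exchanges bromo for ethyl; the single step in hand swaps one ring substituent for another and moved the number by a modest amount. With nothing bearing directly on this change, the expected step of a 1.0-fold lower number from compound 2 to compound 3 (0.02 log units; within the scatter) is none beyond the scatter. Compound 3 is therefore estimated at 6000 nM, within 2500 nM to 15000 nM.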

Compound 3, half-maximal inhibitory concentration: 8270 nM
The estimate for compound 3 lay 1.4-fold (0.14 log units) below the measured number, within the range that was stated.
By their numbers in this assay, from the lowest: compounds 2 and 3 (each within the scatter of the next); then compound 1.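

The step of a 1.3-fold higher number from compound 2 to compound 3 (0.12 log units; within the scatter) shows that in this assay ethyl and bromo on this aromatic carbon cannot be told apart, although ethyl brings two heavy atoms where bromo has one. The step of a 2.7-fold lower number from compound 1 to compound 3 (0.44 log units; beyond the scatter) shows that compound 3, like compound 2, stands apart from compound 1, so the lower number is not tied to bromo alone. Nothing available explains why these two groups read alike. Going by these compounds, whether methoxy, an amine or a longer chain on the same carbon would stay within the scatter of compound 2 remains open.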